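Swapping the hexyloxy tail for a pyridinylmethoxy tail

The source may report more compounds than this note shows. Statements on the series, on what has been measured and on what is new or still open speak of the compounds shown alone.

Measured so far:
compound 1, `CC1CCN(c2nc(C(F)(F)Cl)ccc2CNC(=O)C(C)c2ccc(NS(C)(=O)=O)c(F)c2)CC1`: 0.3 nM
compound 2, `CCCCCCOc1nc(C(F)(F)Cl)ccc1CNC(=O)C(C)c1ccc(NS(C)(=O)=O)c(F)c1`: 0.8 nM

Both were tested in an assay on CHO cells for antagonist activity at transient receptor potential cation channel subfamily V member 1 (Homo sapiens), read by FLIPR; a lower number here means a stronger inhibitor, a higher number a weaker inhibitor. For the measured compounds named here, compound 2 has the higher of the two numbers; the only measured step, a 2.7-fold higher number from compound 1 to compound 2 (0.43 log units; beyond the scatter), is modest. Compound 3, `CC(C(=O)NCc1ccc(C(F)(F)Cl)nc1OCc1cccnc1)c1ccc(NS(C)(=O)=O)c(F)c1`, differs from compound 2 in one place: pyridin-3-yl in place of pentyl on a saturated chain carbon bound to an oxygen on an aromatic ring. Going by the values given here, no measured step covers this change, so the one step above is only a rough guide to how much the tail on this oxygen matters. Compound 3 is expected to stay close to compound 2, with a 1.9-fold higher number from compound 2 to compound 3 (0.27 log units; within the scatter) as the estimated step, giving an estimate of 1.5 nM in the range 0.4 nM to 6 nM.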

Compound 3, inhibition constant: 14.6 nM
Estimate against measurement, compound 3: 9.7-fold (0.99 log units) below; the whole stated range lies below it.
By their numbers in this assay, from the lowest: compound 1; then compound 2; then compound 3.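

For the compounds shown here, the tail on this oxygen turns out to matter far more than the one earlier step suggested: in this assay, (pyridin-3-yl)methoxy in place of hexyloxy gives an 18-fold higher number from compound 2 to compound 3 (1.26 log units; beyond the scatter) and so costs much more than the change between hexyloxy and 4-methylpiperidin-1-yl did. Set against the 4-methylpiperidin-1-yl group, the same tail gives a 49-fold higher number from compound 1 to compound 3 (1.69 log units; beyond the scatter) on the shared core. No available evidence bears on why this tail fares so poorly. Still open, from the compounds shown here alone, is whether a benzyloxy tail, with a plain phenyl ring, would behave like hexyloxy or like (pyridin-3-yl)methoxy. The compounds shown therefore cannot separate the effect of having a ring in the tail from that of the ring nitrogen.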